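Furan for thiophene on the shared core of compound 3

The source may report more compounds than this note shows. Statements on the series, on what has been measured and on what is new or still open speak of the compounds shown alone.

Among the compounds with values here, compound 3 `CC1CCN(c2ccc(Nc3nccc(-c4cccs4)n3)cc2)CC1` carries the lowest number of the three so far measured in a functional assay for inhibition, with Homo sapiens as the target; a higher number here means a weaker inhibitor, a lower number a stronger inhibitor: compound 3 gives 400 nM. Compound 2 `CC1CCN(c2ccc(Nc3nccc(-c4cccnc4)n3)cc2)CC1` stands nearest, with 500 nM, and the step of a 1.3-fold lower number from compound 2 to compound 3 (0.10 log units; within the scatter) is too small to mark any difference. Compound 1 `CN(C)c1ccc(Nc2nccc(-c3ccco3)n2)cc1` differs from compound 3 in two places at once; in this assay compound 1 gives 1900 nM and lies furthest away.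

Compound 4 `CC1CCN(c2ccc(Nc3nccc(-c4ccco4)n3)cc2)CC1` is the next member. It differs from compound 3 only in the five-membered ring: furan-2-yl in place of thiophen-2-yl on an aromatic carbon

Within the data shown here, the one measured step that bears on an exchange of this ring is a 1.3-fold lower number from compound 2 to compound 3 (0.10 log units; within the scatter), and it stayed within the scatter. No measured pair isolates the furan-2-yl for thiophen-2-yl exchange on this core; compound 1, the only compound shown that carries furan-2-yl, differs from compound 3 elsewhere as well, so its higher number cannot be assigned to the ring alone. Given that, the expected step from compound 3 to compound 4 in this assay is small, a 1.4-fold higher number from compound 3 to compound 4 (0.14 log units; within the scatter), with the direction uncertain and at most a slight rise allowed for. Compound 4 is therefore estimated at 550 nM, within a range from 250 nM to 1300 nM.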

Compound 4, half-maximal inhibitory concentration: 1800 nM
Compound 4: middle estimate off by 3.3-fold (0.51 log units), on the low side; measured number outside the range, above it.
By their numbers in this assay, from the lowest: compounds 3 and 2 (each within the scatter of the next); then compounds 4 and 1 (each within the scatter of the next).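

The position is not indifferent to the ring it carries: in this assay the exchange of thiophen-2-yl for furan-2-yl gives a 4.5-fold higher number from compound 3 to compound 4 (0.65 log units; beyond the scatter), although the two groups match in heavy atom count and in hydrogen-bond donors and acceptors, and the comparison with pyridin-3-yl gives a 3.6-fold higher number from compound 2 to compound 4 (0.56 log units; beyond the scatter), so furan-2-yl separates from both of the rings that had stood within the scatter of each other. The other side of the core does not separate once furan-2-yl is fixed: the change from dimethylamino to 4-methylpiperidin-1-yl gives a 1.1-fold lower number from compound 1 to compound 4 (0.02 log units; within the scatter), so the higher number of compound 1 now tracks its furan-2-yl rather than its dimethylamino group, and none of the four compounds goes against this reading. Nothing available explains the gap between the oxygen and sulfur rings.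

Still open, going by these compounds, is whether thiophen-2-yl would bring the same step on the core of compound 1, which would show whether the ring effect carries across both amine groups. Also open, on these data alone, is how this position responds to a plain phenyl ring, to thiazol-2-yl, or to a thiophene bearing an amine or a carboxylic acid.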